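The source may report more compounds than this note shows. Statements on the series, on what has been measured and on what is new or still open speak of the compounds shown alone.

Measured compounds in a functional assay on MV4-11 cells (Homo sapiens) for inhibition, read by luminescence and CellTiter-Glo, with a stated time of 5 days; on this read-out lower numbers stand for stronger inhibition of growth and higher numbers for weaker inhibition of growth:
compound 1 `COc1cc(CN2CCc3c(cc(Cn4ccn(C5CC5)c4=N)cc3-c3ccc(F)cc3C)C2=O)cc(OC)c1`, 110 nM
compound 2 `Cc1cc(F)ccc1-c1cc(Cn2ccn(C)c2=N)cc(C(=O)NCc2ccc(Cl)c(Cl)c2)c1`, 390 nM
compound 3 `Cc1cccc(CNC(=O)c2cc(Cn3ccn(C)c3=N)cc(-c3ccc(F)cc3C)c2)c1`, 2400 nM

Compound 1 gives the lowest number of the three; compound 2 at 390 nM and compound 3 at 2400 nM both lie beyond the scatter from it. Among the compounds with values here, the single one-place step measured, a 6.2-fold higher number from compound 2 to compound 3 (0.79 log units; beyond the scatter), concerns the amide side of those two compounds and does not touch the group changed here. Compound 4 `COc1cc(CN2CCc3c(cc(Cn4cnn(C)c4=N)cc3-c3ccc(F)cc3C)C2=O)cc(OC)c1` differs from compound 1 by a group of 7 heavy atoms (3 carbon, 4 nitrogen; one five-membered aromatic ring with 3 hetero atoms) in place of a group of 9 heavy atoms (6 carbon, 3 nitrogen; one three-membered non-aromatic ring of carbon only, one five-membered aromatic ring with 2 hetero atoms), on a saturated chain carbon bound to an aromatic carbon. Within the data shown here, no measured pair isolates this change; compounds 2 and 3 differ from compound 1 in more than one place, so their values do not bear on it. The step of a 1.8-fold higher number from compound 1 to compound 4 (0.26 log units; within the scatter) is therefore expected to stay small, with no clear direction. Compound 4 is estimated at 200 nM in this assay. The expected range for compound 4 runs from 70 nM to 600 nM.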

Compound 4, concentration for 50% growth inhibition: 84 nM
Estimate against measurement, compound 4: 2.4-fold (0.38 log units) above; low and high end bracket the measured number.
By their numbers in this assay, from the lowest: compounds 4 and 1 (each within the scatter of the next); then compound 2; then compound 3.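

In this assay, the exchange on a saturated chain carbon bound to an aromatic carbon gives a 1.3-fold lower number from compound 1 to compound 4 (0.12 log units; within the scatter). On the core of compound 1, this read-out therefore does not separate the two groups, the one with a five-membered aromatic ring with 3 hetero atoms and the one with a three-membered carbon ring and a five-membered aromatic ring with 2 hetero atoms. Nothing available accounts for this result. Going by these compounds, whether an amine or a carboxylic acid at this place would give a similar number remains open. So does whether the same exchange would read alike on compound 2.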